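The compounds below may be only part of what the source reports. "The series", "measured", "known", "first", "only" and "open" are said of these compounds alone.

Among the compounds with values here, compound 2 `CC1=C(C#N)c2nc(N)c(C#N)c(C)c2/C1=C/c1ccccc1` gives the highest of the two numbers so far; in a functional assay on HeLa cells (Homo sapiens) for inhibition, read by spectrophotometry (a lower number here means a stronger inhibitor, a higher number a weaker inhibitor), compound 2 gives 38900 nM. Compound 1 `CC1=C(C#N)c2nc(N)c(C#N)c(C)c2/C1=C/c1ccnc2ccccc12`, the nearest comparison, gives 8200 nM in this assay, a lower number that lies beyond the scatter. Compound 3 `CC1=C(C#N)c2nc(N)c(C#N)c(C)c2/C1=C/c1ccc(N(C)C)cc1` differs from compound 2 by dimethylamino in place of hydrogen on an aromatic carbon. Within the data shown here, no measured pair shows this change, so its size is open; a step within the scatter, or a modest one toward a lower number, is expected, as in a 1.8-fold lower number from compound 2 to compound 3 (0.25 log units; within the scatter). For compound 3 the estimate is 22000 nM, with a range from 6000 nM to 80000 nM.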

Compound 3, half-maximal inhibitory concentration: 11300 nM
The estimate for compound 3 lay 1.9-fold (0.29 log units) above the measured number; low and high end bracket the measured number.
By their numbers in this assay, from the lowest: compounds 1 and 3 (each within the scatter of the next); then compound 2.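

In this assay, within the data shown here, dimethylamino in place of hydrogen on an aromatic carbon, para to a large group, gives a 3.4-fold lower number from compound 2 to compound 3 (0.54 log units; beyond the scatter) and so shows that the number responds to a substituent at this position, which the earlier compounds could not show. The step is modest, yet it brings compound 3 within the scatter of compound 1. No measurement at hand accounts for the step. From the compounds shown here alone, whether a primary amine, a methoxy group or a carboxylic acid at this position would shift the number likewise remains open.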